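The compounds below may be only part of what the source reports. "The series", "measured", "known", "first", "only" and "open" are said of these compounds alone.

In a functional assay on PC-3 cells (Homo sapiens) for antiproliferative activity, read by MTT assay, with a stated time of 24 h (on this read-out lower numbers stand for stronger inhibition and higher numbers for weaker inhibition), compound 1 `CCn1c(C(=O)NCCC(=O)OC)ccc1C(CC)(CC)c1ccc(OCS(=O)(=O)c2ccccc2)c(C)c1` gives 40400 nM. Compound 2 `CCn1c(C(=O)NCCNC(=O)OC(C)(C)C)ccc1C(CC)(CC)c1ccc(OCS(=O)(=O)c2ccccc2)c(C)c1` reaches only a limit of the assay, > 50000 nM. For the measured compounds named here, compound 3 `CCn1c(C(=O)N[C@H](C)CO)ccc1C(CC)(CC)c1ccc(OCS(=O)(=O)c2ccccc2)c(C)c1` gives 7790 nM, the lowest number so far, with a 5.2-fold lower number from compound 1 to compound 3 (0.71 log units; beyond the scatter) and an at least 6.4-fold lower number from compound 2 to compound 3 (0.80 log units; beyond the scatter). Compound 4 `CCn1c(C(=O)N[C@H](CO)C(C)C)ccc1C(CC)(CC)c1ccc(OCS(=O)(=O)c2ccccc2)c(C)c1` carries a single change, 1-(hydroxymethyl)-2-methylpropyl in place of 1-(hydroxymethyl)ethyl on an amide-type nitrogen. Both measured steps to compound 3 exchange the whole group on that nitrogen, and each is modest or at least modest. Neither tests so small a change, so the expected step is a 1.2-fold lower number from compound 3 to compound 4 (0.08 log units; within the scatter), with none beyond the scatter anticipated. For compound 4 the estimated value is 6500 nM, with an expected range of 2500 nM to 20000 nM.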

Compound 4, half-maximal inhibitory concentration: 7300 nM
Compound 4: the middle estimate sits 1.1-fold (0.05 log units) below what was measured; the range from low to high includes it.
By their numbers in this assay, from the lowest: compounds 4 and 3 (each within the scatter of the next); then compound 1. At a limit, above all of these: compound 2.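

In this assay, 1-(hydroxymethyl)-2-methylpropyl on the amide-type nitrogen reads the same as 1-(hydroxymethyl)ethyl within the scatter, a 1.1-fold lower number from compound 3 to compound 4 (0.03 log units; within the scatter), so this position tolerates the added carbons. Compound 4 also keeps the lower number against 2-(methoxycarbonyl)ethyl, a 5.5-fold lower number from compound 1 to compound 4 (0.74 log units; beyond the scatter), so that gain is not confined to 1-(hydroxymethyl)ethyl. The further step, an at least 6.8-fold lower number from compound 2 to compound 4 (0.83 log units; beyond the scatter), is only a floor, set by a limit and not a number: the limit of > 50000 nM in this assay, at which 1 of the 4 values shown sits.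

Going by these compounds, what a free amine, a carboxylic acid or a longer chain ending in hydroxyl would give on this nitrogen stays open. So does the opposite configuration at the stereocentre.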